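Phenol-bearing aryl groups on the acylhydrazone of compound 1

The source may report more compounds than this note shows. Statements on the series, on what has been measured and on what is new or still open speak of the compounds shown alone.

For the measured compounds named here, compound 1 `CN(C)CCn1cnnc1-c1cc(Oc2ccc(NC(=O)N/N=C/c3ccc(Cl)cc3)cc2F)ccn1` carries a 4-chlorophenyl group on a carbon with a double bond to nitrogen; in a functional assay on A549 cells (Homo sapiens) for cytotoxicity, read by MTT assay, with a stated time of 72 h (a lower number here means a stronger inhibitor, a higher number a weaker inhibitor), compound 1 gives 780 nM, the only number among the three values shown. Compound 2 `CN(C)CCn1cnnc1-c1cc(Oc2ccc(NC(=O)N/N=C/c3cc(Br)c(O)c(Br)c3)cc2F)ccn1` in this assay gives the limit > 100000 nM. Compound 3 `COc1cc(/C=N/NC(=O)Nc2ccc(Oc3ccnc(-c4nncn4CCN(C)C)c3)c(F)c2)ccc1O` in this assay likewise gives the limit > 100000 nM. The steps of an at least 120-fold higher number from compound 1 to compound 2 (2.10 log units; beyond the scatter) and an at least 120-fold higher number from compound 1 to compound 3 (2.10 log units; beyond the scatter) both end at the limit of > 100000 nM in this assay, at which 2 of the 3 values shown sit. Compound 4 `CN(C)CCn1cnnc1-c1cc(Oc2ccc(NC(=O)N/N=C/c3ccc(O)cc3O)cc2F)ccn1` differs from compound 1 in that (2,4-dihydroxyphenyl in place of 4-chlorophenyl on a carbon with a double bond to nitrogen). Both measured steps exchange the 4-chlorophenyl for a hydroxylated ring and both are large losses, so a large rise in this assay is expected for compound 4 as well, with a real chance of a limit. Compound 4 is therefore estimated at 80000 nM (8000 nM to 300000 nM), an expected step of a 100-fold higher number from compound 1 to compound 4 (2.01 log units; beyond the scatter).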

Compound 4, half-maximal inhibitory concentration: 12700 nM
Compound 4: middle estimate off by 6.3-fold (0.80 log units), on the high side; low and high end bracket the measured number.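

In this assay, a hydroxylated ring at this position does not always end at the limit, as the 2,4-dihydroxyphenyl of compound 4 gives a readable number, though replacing 4-chlorophenyl still brings a large loss (a 16-fold higher number from compound 1 to compound 4 (1.21 log units; beyond the scatter)). The hydroxylated rings also differ among themselves (an at least 7.8-fold lower number from compound 3 to compound 4 (0.89 log units; beyond the scatter); an at least 7.8-fold lower number from compound 2 to compound 4 (0.89 log units; beyond the scatter)). For compound 2 and compound 3 the values remain limits, not numbers: (the limit of > 100000 nM in this assay, at which 2 of the 4 values shown sit).

The step between compound 2 and compound 3 cannot be read. On these data alone, how a ring carrying an amine or a carboxylic acid would read here stays open.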